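Removing the benzyl ether from a long-chain amino alcohol

The source may report more compounds than this note shows. Statements on the series, on what has been measured and on what is new or still open speak of the compounds shown alone.

Among the measured compounds shown here, the two compounds measured so far share a long saturated chain bearing a nitrogen and an oxygen on neighbouring carbons. Compound 1 `CCCCCCCCCCCCCCC(N)CO` carries a primary amine and a free hydroxyl group. In an ADME assay on cells (Splenocyte, Mus musculus, strain BALB/c) for cytotoxicity, read by MTT assay, tested at 10 ug/mL (on this read-out higher numbers stand for a stronger effect at the one concentration tested and lower numbers for a weaker effect), compound 1 gives 20.2%. Compound 2 `CCCCCCCCCCCCCCC(COCc1ccccc1)N(CC)CC` instead carries a diethylamino group and a benzyl ether on the oxygen. In this assay compound 2 gives 15.6%. The numbers for compound 2 and compound 1 lie within the scatter of each other, so the data show no difference between them.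

Compound 3 `CCCCCCCCCCCCCCC(CO)N(CC)CC` has not yet been measured. It differs from compound 2 by a single change: hydrogen in place of benzyl on an oxygen on a saturated carbon. The difference cut one bond further out reads benzyloxy to hydroxy. For the measured compounds named here, no step between measured compounds tells what this change does on its own. The hydroxymethyl group of compound 3 is also present in compound 1, whose value of 20.2% sits close to that of compound 2. For that reason the expected step of a number 2.4 percentage points higher from compound 2 to compound 3 (within the scatter) is small, with no direction beyond the scatter. Compound 3 is estimated to give 18%, within a range from 8% to 30%.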

Compound 3, a percentage reported as activity, at one concentration (the size of the read-out at that concentration, not a potency): 12.8%
Compound 3: the middle estimate sits 5.2 percentage points above what was measured; measured number inside the range.
By their numbers in this assay, from the lowest: compounds 3, 2 and 1 (each within the scatter of the next).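

In this assay, hydrogen in place of benzyl on an oxygen on a saturated carbon gives a number 2.8 percentage points lower from compound 2 to compound 3 (within the scatter), so the exchange of benzyloxy to hydroxy now has a direct reading of its own, and that reading shows no difference between the two compounds. The new compound also gives a second single-place comparison at the nitrogen: diethylamino in place of amino on a saturated chain carbon bound to two saturated chain carbons gives a number 7.4 percentage points lower from compound 1 to compound 3 (within the scatter), so neither of the two single changes separates the compounds on this read-out. No measurement at hand bears on why these results came out as they did.

The compounds shown leave open whether other groups on this oxygen, such as a methyl ether or an acetate ester, would also read within the scatter of compound 3. They also leave open whether a carboxylic acid in place of the hydroxymethyl group, or a dimethylamino group in place of the diethylamino group, would give a step beyond the scatter.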